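One methyl added to compound 1

The source may hold more compounds than are shown below. What is called first, only, known or untested is meant among the compounds shown, and "the series" means these compounds.

Compound 1 (`O=C(O)Cc1nn(Cc2cn3cc(OCC4CC4)c(Cl)cc3n2)c2ccccc2c1=O`) has the lowest of three numbers in a physicochemical assay for lipophilicity, at pH 7.4 (a lower number here means a more polar compound, a higher number a more lipophilic compound), at 2.13. Compound 2 (`C[C@H](C(=O)O)n1nc(Cn2cc3cc(OCC4CC4)c(Cl)cc3n2)c2ccccc2c1=O`) gives 2.99 and compound 3 (`O=C(Cc1nn(C2CC2)c(=O)c2ccccc12)Nc1ccc(OC(F)(F)F)c(Cl)c1`) gives 5.43, both higher by more than the usual scatter. Compound 4 (`C[C@H](C(=O)O)c1nn(Cc2cn3cc(OCC4CC4)c(Cl)cc3n2)c2ccccc2c1=O`) departs from compound 1 in one place: methyl in place of hydrogen on a saturated chain carbon bound to an aromatic carbon and a carbonyl carbon, which turns carboxymethyl to 1-carboxyethyl. Within the data shown here, no measured pair shows this change alone. Compound 2 also carries a 1-carboxyethyl group and gives 2.99, though its structure differs in other ways as well. A small rise, only slightly beyond the scatter, is expected in this assay, a number 0.37 log units higher from compound 1 to compound 4 (beyond the scatter). For compound 4 the estimated value is 2.5, with an expected range from 2.2 to 2.9.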

Compound 4, distribution coefficient: 2.39
Estimate against measurement, compound 4: 0.11 log units above, and the stated range covers the measured number.
By their numbers in this assay, from the lowest: compounds 1 and 4 (each within the scatter of the next); then compound 2; then compound 3.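

Among these compounds, this is the first pair in which carboxymethyl becomes 1-carboxyethyl with nothing else altered, and in this assay the methyl on this saturated chain carbon gives a number 0.26 log units higher from compound 1 to compound 4 (within the scatter). Among the compounds shown here, at this position, then, the single added carbon leaves compound 1 and compound 4 indistinguishable in this measurement. Nothing measured here offers an explanation for this result.

The compounds shown leave open how an ethyl group or a second methyl on this carbon would read. They also leave open how a hydroxyl group there would compare.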